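The compounds below may be only part of what the source reports. "The series", "measured", "known", "first", "only" and "open" are said of these compounds alone.

The series gathers two measured hydroxamic acids and one untested relative. Compound 1 (`CC(C)(C)c1ccc(CN(C(=O)CN(Cc2ccccc2C(F)(F)F)S(=O)(=O)c2ccc(F)c(F)c2)c2ccc(C(=O)NO)cc2)cc1`) carries a 4-(tert-butyl)benzyl group on the amide nitrogen. In an assay on Sf9 cells for inhibition of histone deacetylase 8 (Homo sapiens), read by mobility shift assay (a lower number here means a stronger inhibitor, a higher number a weaker inhibitor), compound 1 gives only a limit, > 1000 nM, and no number. Compound 2 (`O=C(NO)c1ccc(N(Cc2ccc(C(F)(F)F)cc2)C(=O)CN(Cc2ccccc2C(F)(F)F)S(=O)(=O)c2ccc(F)cc2F)cc1`) carries a 4-(trifluoromethyl)benzyl group in that position. In this assay compound 2 likewise reaches only a limit, > 1000 nM, so its standing among the numbers shown cannot be ranked; the one further value shown is also a limit, and both sit at the limit of > 1000 nM in this assay, at which 2 of the 2 values shown sit.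

Compound 3 (`CC(C)(C)c1ccc(CN(C(=O)CN(Cc2ccccc2C(F)(F)F)S(=O)(=O)c2ccc(F)cc2F)c2ccc(C(=O)NO)cc2)cc1`) differs from compound 2 in one place: tert-butyl in place of trifluoromethyl on an aromatic carbon, para to a large group. Going by the values given here, no measured pair shows this step, so its size in this assay is unknown; since compound 1 already holds the tert-butyl group with a limit of > 1000 nM, no move beyond the scatter is expected. The step that the limit leaves unreadable from compound 2 to compound 3 is therefore expected to be flat. Compound 3 is estimated at 3000 nM, within 1000 nM to 10000 nM.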

Compound 3, half-maximal inhibitory concentration: > 1000 nM
Compound 3 ended at the assay's limit; the forecaster's own chance of this, stated with the estimate: 80%; the middle value is on the limit's open side.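

In this assay compound 3 also gives only a limit, > 1000 nM, and no number. No step from compound 2 or compound 1 to compound 3 can therefore be read, as all three compounds share one limit: the limit of > 1000 nM in this assay, at which 3 of the 3 values shown sit.

The compounds shown leave open whether exchanging trifluoromethyl for tert-butyl, or 3,4-difluorophenyl for 2,4-difluorophenyl, shifts inhibition at all.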